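Amide nitrogen substituent change on the shared core

The compounds below may be only part of what the source reports. "The series", "measured", "known", "first", "only" and "open" are said of these compounds alone.

Two compounds of this series have been run in an ADME assay on RAW264.7 cells (Mus musculus) for cytotoxicity, read by MTT assay, with a stated time of 72 h, tested at 100 uM; on this read-out lower numbers stand for a weaker effect and higher numbers for a stronger effect at the one concentration tested. Compound 1 `O=C(Cn1c(=O)oc2ccccc21)NCc1ccccn1` gives 38.7% in this assay, the higher of the two numbers obtained so far. Compound 2 `O=C(Cn1c(=O)oc2cc(Cl)ccc21)Nc1cc(C(F)(F)F)ccc1Cl` gives 12.1% in this assay, which lies a gap below compound 1 that is beyond the usual scatter; compound 2 differs from compound 1 in more than one place, so the two values are taken only as they stand. Compound 3 `O=C(Cn1c(=O)oc2ccccc21)Nc1ccccc1` has not been measured yet. It differs from compound 1 by phenyl in place of (pyridin-2-yl)methyl on an amide-type nitrogen. For the measured compounds named here, no pair of measured compounds differs in this one place alone, so no measured step can be carried over to this change, and the shared core of compound 1 is kept. The working expectation is a small drop from compound 1 to compound 3, or none beyond the scatter. For compound 3 the estimate in this assay is 31%, with a range of 12% to 50%. This estimate means an expected a number 7.7 percentage points lower from compound 1 to compound 3 (within the scatter).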

Compound 3, a percentage reported as inhibition, at one concentration (the size of the read-out at that concentration, not a potency): 39.8%
Compound 3: middle estimate off by 8.8 percentage points, on the low side, and the stated range covers the measured number.
By their numbers in this assay, from the lowest: compound 2; then compounds 1 and 3 (each within the scatter of the next).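

Phenyl in place of (pyridin-2-yl)methyl on the amide-type nitrogen gives the first step in the series that differs in one place only: in this assay, the step is a number 1.1 percentage points higher from compound 1 to compound 3 (within the scatter). At this position, then, the read-out at the one concentration tested does not separate the six-membered aromatic ring of carbon only from the ring with 1 hetero atom, even though the swap also removes the hydrogen-bond acceptor counted for the group that leaves. No measured property at hand accounts for this likeness between the two substituents.

This single step changes the ring and the methyl link together, so it cannot show what each contributes alone or whether their contributions offset each other; benzyl on the same nitrogen would separate the two. Also open, on these data alone, is whether this position stays as flat with a group of another kind, such as a longer chain like 2-phenylethyl, a saturated ring like cyclohexyl, or a chain ending in an amine or a carboxylic acid.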